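Swapping the indole for a dimethylphenyl in an enone sulfone series

This account rests on a few compounds, and the source may have more. Where it says the series, first, only, none or still open, it means among the compounds named here.

The study centres on growth inhibition of a prostate-derived cell line. The read-out is a functional assay on DU-145 cells (Homo sapiens) for inhibition, read by trypan blue exclusion, with a stated time of 96 h; a lower number here means a stronger inhibitor of growth, a higher number a weaker inhibitor of growth. Compound 1, `O=C(/C(=C\c1ccc([N+](=O)[O-])c(O)c1)SCc1ccc(Br)cc1)c1ccc(Br)cc1`, carries a nitrophenol on one end of its enone and a thioether on the other; in this assay compound 1 gives 10000 nM. Compound 2, `Cc1ccc(CS(=O)(=O)/C(=C/c2c[nH]c3ccc(Br)cc23)C(=O)c2ccc(Cl)cc2)cc1`, replaces the thioether with a sulfone and carries a brominated indole on the double-bonded chain; in this assay compound 2 gives 10000 nM. On the numbers shown, compound 2 stands level with compound 1, and the two values lie within the usual scatter of each other, so no order between them can be claimed.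

Compound 3, `Cc1ccc(CS(=O)(=O)/C(=C/c2cc(C)ccc2C)C(=O)c2ccc(Cl)cc2)cc1`, keeps the sulfone and the chlorophenyl ketone of compound 2 and differs from it in one place: 2,5-dimethylphenyl in place of 5-bromo-1H-indol-3-yl on a double-bonded chain carbon bound to a double-bonded chain carbon

For the measured compounds named here, because compound 2 gives 10000 nM and no step between measured compounds is available to calibrate this change, the expected step from no change at the digits printed from compound 2 to compound 3 (within the scatter) is none beyond the scatter. In this assay compound 3 is expected to give 10000 nM, in a range from 3000 nM to 30000 nM.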

Compound 3, concentration for 50% growth inhibition: 1000 nM
For compound 3 the middle estimate is 10-fold (1.00 log units) above the measured one, outside the stated range (below it).
By their numbers in this assay, from the lowest: compound 3; then compounds 1 and 2 (each within the scatter of the next).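

In this assay, exchanging the 5-bromo-1H-indol-3-yl group for 2,5-dimethylphenyl gives a 10-fold lower number from compound 2 to compound 3 (1.00 log units; beyond the scatter). This is the first step beyond the scatter among the compounds shown, and it makes this position one where the choice of group alters the read-out while the sulfone and the chlorophenyl ketone stay fixed. For the compounds shown here, the single step removes the five-membered aromatic ring, the hydrogen-bond donor and the bromine together and brings in two methyl groups, so it cannot assign the difference to any one of these parts, and nothing available bears on why the number falls.

The compounds shown leave open whether a plain phenyl, a phenyl with a single methyl group or a 1H-indol-3-yl group without the bromine would give a number nearer to that of compound 2 or of compound 3. They also leave open whether a methoxy group or a chlorine atom in place of either methyl group would carry the lower number further or lose it.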